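This account rests on a few compounds, and the source may have more. Where it says the series, first, only, none or still open, it means among the compounds named here.

Compound 1 `O=C(Nc1cccc(-c2nc3ccccc3s2)c1)c1cc([N+](=O)[O-])ccc1Cl`: > 27000 nM (a limit)
Compound 2 `COc1ccc(NC(=O)c2cc([N+](=O)[O-])ccc2Cl)cc1-c1nc2ccccc2s1`: > 25000 nM (a limit)

In an ADME assay on BJ cells (Homo sapiens) for cytotoxicity, with a stated time of 72 h (a higher number here means that more compound is needed for the effect, a lower number that less compound is needed), compound 1 stands only at a limit, > 27000 nM. Compound 2 also gives only a limit, > 25000 nM. Compound 3 `Cc1c(NC(=O)c2cc([N+](=O)[O-])ccc2Cl)cccc1-c1nc2ccccc2s1` follows from compound 1 through (methyl in place of hydrogen on an aromatic carbon), methyl in place of hydrogen on an aromatic carbon. Going by the values given here, the one measured step that bears on this change is a step that the two limits leave unreadable from compound 1 to compound 2, with methoxy in place of hydrogen, so its size offers no guide. No step beyond the scatter is therefore expected, and the estimated outcome is a number no higher from compound 1 to compound 3 (the limit leaves the size open). Compound 3 is expected at 27000 nM, with an estimated range from 10000 nM to 50000 nM.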

Compound 3, half-maximal effective concentration: > 25000 nM
Compound 3 ended at the assay's limit; the forecaster's own chance of this, stated with the estimate: 80%; the middle value does not contradict the limit.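

The step between compound 1 and compound 3 cannot be read, as both values are limits. The compounds shown leave open where the half-maximal effective concentration of compound 1, compound 2 or compound 3 actually lies, and whether methyl or methoxy changes it.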